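The source may hold more compounds than are shown below. What is called first, only, known or untested is meant among the compounds shown, and "the series" means these compounds.

Measured compounds:
compound 1 `CCN(CC)CCNC(=O)Nc1nc2ccc(-c3cnc(OC)c(NS(=O)(=O)c4ccc(F)cc4)c3)cc2s1`: 390 nM
compound 2 `COc1ncc(-c2ccc3nc(NC(=O)NC4CC4)sc3c2)cc1NS(=O)(=O)c1ccc(F)cc1`: 520 nM

In a functional assay on U-87MG ATCC cells for antiproliferative activity against U-87 MG (Homo sapiens), read by MTT assay, with a stated time of 72 h (on this read-out higher numbers stand for weaker inhibition and lower numbers for stronger inhibition), compound 1 gives 390 nM and compound 2 gives 520 nM. Among the compounds with values here, compound 1 stands alongside compound 2; the only measured step, a 1.3-fold higher number from compound 1 to compound 2 (0.12 log units; within the scatter), is within the scatter, so the two are not separated by these data.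

Compound 3 `CCN(CC)CCNC(=O)Nc1nc2ccc(-c3cnc(Cl)c(NS(=O)(=O)c4ccc(F)cc4)c3)cc2s1` is not yet measured. It differs from compound 1 by chloro in place of methoxy on an aromatic carbon, the change sitting on an aromatic carbon of a six-membered aromatic ring with 1 nitrogen, next to the ring nitrogen and ortho to the ((4-fluorophenyl)sulfonyl)amino group. Within the data shown here, the measured step concerns the urea nitrogen on the other side of the shared core and does not touch this position, so no measured step bears on the change. With nothing to anchor a shift either way, the expected step is a 1.3-fold higher number from compound 1 to compound 3 (0.11 log units; within the scatter), none beyond the scatter. For compound 3 the estimate in this assay is 500 nM, in the range 150 nM to 1700 nM.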

Compound 3, half-maximal inhibitory concentration: 1390 nM
Beside the measured number, compound 3's estimate is 2.8-fold (0.44 log units) below it; measured number inside the range.
By their numbers in this assay, from the lowest: compounds 1 and 2 (each within the scatter of the next); then compound 3.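

In this assay, replacing methoxy with chloro on the aromatic carbon next to the ring nitrogen gives a 3.6-fold higher number from compound 1 to compound 3 (0.55 log units; beyond the scatter), a modest loss of inhibition. Within the data shown here, this step clears the scatter, whereas the earlier change on the amide-type nitrogen, a 1.3-fold higher number from compound 1 to compound 2 (0.12 log units; within the scatter), does not, so this carbon is the first place where a single change separates two compounds. Nothing available bears on the reason for this difference between methoxy and chloro.

Going by these compounds, with only these two groups compared here, it remains open whether fluoro, an amine or a longer alkoxy chain such as ethoxy on this carbon would fall nearer to methoxy or to chloro. Also open, on these data alone, is whether the step from methoxy to chloro holds when cyclopropyl replaces 2-(diethylamino)ethyl on the amide-type nitrogen.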